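A few compounds are considered here, and "the series" means these few. Any claim that something is new, unique, unknown or untested is made for them only; others in the source may bear on it.

Within the data shown here, in a functional assay on HeLa cells (Homo sapiens) for antiproliferative activity, read by cell counting, with a stated time of 3 days (a lower number here means a stronger inhibitor, a higher number a weaker inhibitor), compound 2 `CC(Nc1ccccc1Oc1ccccc1)=C1C(=O)CC(c2ccccc2)CC1=O` gives 79 nM and holds the lower of the two numbers measured so far. Among the measured compounds shown here, the only other measured compound is compound 1 `CC(Nc1ccccc1Oc1cccc(F)c1)=C1C(=O)CC(c2ccccc2)CC1=O` with 550 nM as its result. One measured step joins them, a 7.0-fold lower number from compound 1 to compound 2 (0.84 log units; beyond the scatter) for hydrogen in place of fluoro on an aromatic carbon.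

The next compound is compound 3 `CCOc1ccccc1NC(C)=C1C(=O)CC(c2ccccc2)CC1=O` and its change from compound 2 is ethyl in place of phenyl on an oxygen on an aromatic ring so phenoxy becomes ethoxy.

The measured step bears on this only indirectly. For the measured compounds named here, the fluoro of compound 1 sits on the same phenyl that leaves here, yet no measured compound lacks that phenyl. Even so, that smaller edit gave a 7.0-fold lower number from compound 1 to compound 2 (0.84 log units; beyond the scatter) and the loss of the whole phenyl is therefore expected to give a step of similar or larger size toward a higher number in this assay with wide uncertainty. The expected change is an 8.9-fold higher number from compound 2 to compound 3 (0.95 log units; beyond the scatter) as an estimate. For compound 3 the estimated value is 700 nM (expected range 180 nM to 3000 nM).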

Compound 3, half-maximal inhibitory concentration: 180 nM
The estimate for compound 3 lay 3.9-fold (0.59 log units) above the measured number; measured number inside the range.
By their numbers in this assay, from the lowest: compound 2; then compound 3; then compound 1.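

In this assay, the phenyl on this oxygen turns out not to be essential for a low number: replacing it with ethyl costs only a 2.3-fold higher number from compound 2 to compound 3 (0.36 log units; beyond the scatter), so a small chain with no ring keeps much of the activity of compound 2. The same position also tolerates ethyl better than 3-fluorophenyl, with a 3.1-fold lower number from compound 1 to compound 3 (0.49 log units; beyond the scatter), which places the ethoxy compound between the two aryl ethers and shows that keeping an aromatic ring here does not by itself give the lower number, since compound 1 has one and still stands highest of the three. No measurement of any other kind accompanies these numbers, so the order of the three compounds remains a description and carries no explanation.

The compounds shown leave open how the number changes with the size of the group on this oxygen, for instance with a methyl, a longer chain such as butyl, or a saturated ring such as cyclohexyl. They also leave open whether the penalty seen with fluoro is particular to that atom or would recur with chloro or methoxy on the phenyl.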